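The compounds below may be only part of what the source reports. "The series", "measured", "known", "first", "only" and "open" are said of these compounds alone.

Measured compounds:
compound 1 `CC(=O)OC/C(=C\c1ccc(Cl)cc1Cl)C(=O)c1ccc(Cl)cc1`: 3200 nM
compound 2 `CC(=O)OC/C(=C/c1ccc(Cl)cc1Cl)C(=O)c1ccccc1`: 23000 nM
compound 3 `CC(=O)OC/C(=C/c1ccc(Cl)cc1)C(=O)c1ccc(Cl)cc1`: 16000 nM

All three were tested in a functional assay on HBL-100 cells (Homo sapiens) for inhibition, read by sulforhodamine B assay, with a stated time of 48 h; on this read-out lower numbers stand for stronger inhibition of growth and higher numbers for weaker inhibition of growth. Compound 3 stands second highest of the three numbers. Its nearest neighbour is compound 2, whose value of 23000 nM lies within the scatter of the value of compound 3, so no order between these two can be read. Its furthest neighbour is compound 1, which with 3200 nM sits beyond the scatter on the lower side, and compound 1 is the only one of the three that carries a 2,4-dichlorophenyl group.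

The next compound, compound 4 `CC(=O)OC/C(=C/c1ccc(Cl)cc1Cl)C(=O)c1ccc(Cl)cc1`, has not been measured in this assay. Against compound 3 the change is chloro in place of hydrogen on an aromatic carbon. Going by the values given here, no step between measured compounds shows this exact change, so its size has to be inferred. Since compound 1 with the same 2,4-dichlorophenyl group gives 3200 nM while compound 3 gives 16000 nM, the expectation is a shift towards lower numbers, of a size that probably reaches beyond the scatter, though compound 1 differs from compound 4 elsewhere, so the expected step of a 2.7-fold lower number from compound 3 to compound 4 (0.43 log units; beyond the scatter) is held moderate. For compound 4 the estimated value in this assay is 6000 nM, with an expected range from 2000 nM to 20000 nM.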

Compound 4, concentration for 50% growth inhibition: 22000 nM
Beside the measured number, compound 4's estimate is 3.7-fold (0.56 log units) below it; measured number above the stated range.
By their numbers in this assay, from the lowest: compound 1; then compounds 3, 4 and 2 (each within the scatter of the next).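

In this assay, the change from 4-chlorophenyl to 2,4-dichlorophenyl, with chloro on an aromatic carbon ortho to a large group, gives no readable shift: a 1.4-fold higher number from compound 3 to compound 4 (0.14 log units; within the scatter). The same exchange of hydrogen for chloro at a different aromatic carbon gives no readable shift either: a 1.0-fold lower number from compound 2 to compound 4 (0.02 log units; within the scatter). Going by these compounds alone, the only step here beyond the scatter is a 6.9-fold higher number from compound 1 to compound 4 (0.84 log units; beyond the scatter), so the lower number of compound 1 goes with its double bond drawn E rather than Z and not with the 2,4-dichlorophenyl group, which compound 4 carries as well, because of this: the fact that compounds 1 and 4 differ only in the configuration as drawn.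

Within the data shown here, whether the E configuration also goes with lower numbers in the frames of compound 2 and compound 3 stays open; the pair of compound 1 and compound 4 is the only such pair in this set. Also open, from the compounds shown here alone, is how an amine or a carboxylic acid would read at the position of the new chloro, since only hydrogen and chloro are compared there.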